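Pyridin-2-yl for pyrimidin-2-yl: cytotoxicity in MT2 cells

The compounds below may be only part of what the source reports. "The series", "measured", "known", "first", "only" and "open" are said of these compounds alone.

Measured compounds:
compound 1, `CC(C)=CCOc1cc(Nc2ccccn2)ccc1C#N`, 290 nM
compound 2, `CC(C)=CCOc1cc(Nc2ncccn2)ccc1C`, 78000 nM

Both compounds were run in a functional assay on MT2 cells (Homo sapiens) for cytotoxicity; a lower number here means that less compound is tolerated, a higher number that more compound is tolerated. Compound 2 holds the highest of the two numbers; its nearest neighbour is compound 1, whose number is far lower, well beyond the scatter. For the measured compounds named here, no pair of measured compounds differs in a single place, so no measured step is available.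

Compound 3, `CC(C)=CCOc1cc(Nc2ccccn2)ccc1C`, has not yet been measured in this assay. Relative to compound 2 the change is pyridin-2-yl in place of pyrimidin-2-yl on a nitrogen on an aromatic ring.

Going by the values given here, with no measured step for this change, the expectation rests on the only other number: compound 1 gives 290 nM, and compound 1 also carries pyridin-2-yl on the nitrogen. On that basis compound 3 is expected to give a lower number than compound 2, a step of a 9.8-fold lower number from compound 2 to compound 3 (0.99 log units; beyond the scatter), beyond the scatter, but likely not all the way down to compound 1. Compound 3 is estimated at 8000 nM, within the range 1000 nM to 60000 nM.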

Compound 3, half-maximal cytotoxic concentration: 35000 nM
For compound 3 the middle estimate is 4.4-fold (0.64 log units) below the measured one, within the range that was stated.
By their numbers in this assay, from the lowest: compound 1; then compound 3; then compound 2.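

In this assay the group on the nitrogen on an aromatic ring now has a measured step of its own: pyridin-2-yl in place of pyrimidin-2-yl gives a modest change (a 2.2-fold lower number from compound 2 to compound 3 (0.35 log units; beyond the scatter)). Methyl in place of cyano on an aromatic carbon gives a much larger one (a 120-fold higher number from compound 1 to compound 3 (2.08 log units; beyond the scatter)), so on the steps shown the group on that aromatic carbon counts for far more in this read-out than the choice between pyridin-2-yl and pyrimidin-2-yl. Nothing at hand accounts for the size of either step.

Going by these compounds, whether the step from methyl to nitrile keeps its size with pyrimidin-2-yl on the nitrogen stays open. Also open, on these data alone, is where other groups on that aromatic carbon, such as a chlorine, a methoxy group or a carboxylic acid, would fall in this assay, and whether a phenyl ring on the nitrogen would stay as close to pyridin-2-yl as pyrimidin-2-yl does.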